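This account rests on a few compounds, and the source may have more. Where it says the series, first, only, none or still open, it means among the compounds named here.

Four compounds are in view here, three of them measured. Compound 1 `CNC(=O)/C=C1\CCc2ccc(Br)cc21` has a core of its own, while compound 2 `CN(C)C(=O)/C=C1\CCc2c(F)cc(F)cc21` and compound 3 `CNC(=O)/C=C1\CCc2c(F)cc(F)cc21` share a second core; the difference between the two cores is not broken down here. All three were tested in a functional assay on the whole organism with Mus musculus as the target, at a dose of 100 mg/kg by the intraperitoneal route; on this read-out higher numbers stand for more inhibition at the one dose given (going by the name of the read-out) and lower numbers for less inhibition. In this assay compound 1 gives 0%. In this assay compound 2 gives 100%, and compound 3 gives 100%. Compound 1 thus stands alone at the bottom, with both other compounds far beyond the scatter above it.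

Between compound 2 and compound 3 one change is made: hydrogen in place of methyl on an amide-type nitrogen. The outcome of that change is no change at the digits printed from compound 2 to compound 3 (within the scatter).

The unmeasured compound 4 `NC(=O)/C=C1\CCc2ccc(Br)cc21` is reached from compound 1 by a change of the same kind: hydrogen in place of methyl on an amide-type nitrogen. The surroundings of the place are not identical, though. Going by the values given here, in compound 2 the nitrogen's other neighbours are a carbonyl carbon and a saturated chain carbon, whereas in compound 1 the only other neighbour is a carbonyl carbon, so the two changes are the same kind of change rather than the same change.

For compound 4 the expected step is a number 5 percentage points higher from compound 1 to compound 4 (within the scatter), because no change at the digits printed from compound 2 to compound 3 (within the scatter) gave no movement for the same kind of change and because compound 1 starts from 0%. Compound 4 is therefore estimated at 5% in this assay, with a likely range from 0% to 35%.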

Compound 4, a percentage reported as inhibition, in the whole organism at one dose (the size of the read-out at that dose, not a potency): 100%
For compound 4 the middle estimate is 95 percentage points below the measured one, outside the stated range (above it).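

In this series, swapping methyl for hydrogen on the amide nitrogen cannot be carried from one core to the other as a fixed step in this assay: the same change on two cores in this assay, no change at the digits printed (within the scatter) from compound 2 to compound 3 and a number 100 percentage points higher (beyond the scatter) from compound 1 to compound 4, 100 percentage points apart, beyond the scatter of two such steps

On the core of the bromine-bearing pair the step is a number 100 percentage points higher from compound 1 to compound 4 (beyond the scatter), so a flat result on one core gave no safe guide to the other. What this does not show is that the two cores truly differ in how they respond to the change, since compound 2 already gives 100%, which leaves this read-out no room to rise, and a single pair on each core cannot reveal why the steps differ.

The compounds shown leave open how the plain amide, with hydrogens only on its nitrogen, behaves on the core shared by compound 2 and compound 3, where a lower-dose test would be needed to separate compounds that all sit at the top of the scale. They also leave open whether the dimethyl amide on the core of compound 1 follows compound 4 or compound 1, and what a longer chain such as ethyl on the amide nitrogen would do.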